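The source may hold more compounds than are shown below. What is called first, only, known or untested is meant among the compounds shown, and "the series" means these compounds.

Working notes on the series.

Of the compounds shown here, three of the shared core have been measured in a functional assay on MCF7 cells (Homo sapiens) for cytotoxicity, read by sulforhodamine B assay; a higher number here means a weaker inhibitor, a lower number a stronger inhibitor. Compound 1 `C=C1[C@@H](OC(C)=O)C[C@@H]2[C@](C)(CO[Si](C)(C)C(C)(C)C)[C@H](OC(C)=O)CC[C@@]2(C)[C@@H]1C[C@@H](Nc1ccccc1)C1=CCOC1=O` gives 4840 nM in this assay, the lowest of the three numbers. Compound 2 `C=C1[C@@H](C/C=C2/C(=O)OC[C@H]2OC(C)=O)[C@]2(C)CC[C@@H](OC(C)=O)[C@@](C)(CO[Si](C)(C)C(C)(C)C)[C@H]2C[C@@H]1O` gives 6960 nM in this assay, within the scatter of compound 1, so no order between these two is claimed. Compound 3 `C=C1[C@@H](OC(C)=O)C[C@@H]2[C@](C)(COC=O)[C@H](OC(C)=O)CC[C@@]2(C)[C@@H]1C[C@@H](Nc1ccccc1C(=O)O)C1=CCOC1=O` gives 30800 nM in this assay, a gap to compound 1 that lies beyond the scatter. Among the compounds with values here, no pair among the measured compounds differs in only one place, so no single structural step has a measured size here.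

Compound 4 `C=C1[C@@H](OC(C)=O)C[C@@H]2[C@](C)(CO[Si](C)(C)C(C)(C)C)[C@H](OC(C)=O)CC[C@@]2(C)[C@@H]1C[C@@H](Nc1cccc2ccccc12)C1=CCOC1=O` is the next to be measured. It differs from compound 1 in one place: naphthalen-1-yl in place of phenyl on an amine nitrogen. The change sits on the anilino nitrogen, a ring growing from one six-membered aromatic ring of carbon to two. Within the data shown here, nothing among the measured compounds shows the effect of such a change; the only measured variation at the anilino group, compound 3 against compound 1, also carries other differences.

Among the measured compounds shown here, with no comparable step available, the expectation for compound 4 rests on compound 1 alone: a step from compound 1 to compound 4 of about a 1.2-fold lower number from compound 1 to compound 4 (0.08 log units; within the scatter) is expected, not clearly beyond the scatter in either direction. Compound 4 is therefore estimated at 4000 nM in this assay, with a range from 1500 nM to 12000 nM.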

Compound 4, half-maximal inhibitory concentration: 5770 nM
Compound 4: the middle estimate sits 1.4-fold (0.16 log units) below what was measured; the range from low to high includes it.
By their numbers in this assay, from the lowest: compounds 1, 4 and 2 (each within the scatter of the next); then compound 3.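

In this assay, within the data shown here, the exchange of phenyl for naphthalen-1-yl on the amine nitrogen gives the first measured single step at this position: a 1.2-fold higher number from compound 1 to compound 4 (0.08 log units; within the scatter) for this change. Two six-membered aromatic rings of carbon in place of one therefore leave compound 4 and compound 1 not separated by this read-out, so this step gives no order between them. Nothing on hand offers an account of this result, and none is attempted here.

From the compounds shown here alone, what a benzyl or cyclohexyl group on the same amine nitrogen would give remains open, as does the isomeric naphthalen-2-yl group. Equally open, going by these compounds, is how a methoxy or dimethylamino group carried on the phenyl ring of compound 1 would read in this assay on the shared core.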